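The source may hold more compounds than are shown below. What is called first, only, known or untested is meant among the compounds shown, and "the series" means these compounds.

Working notes on the series.

For the measured compounds named here, compound 1 `CS(=O)(=O)Nc1ccc2c(c1)S(=O)(=O)N=C(C1=C(O)C3CCCC3N(Cc3ccc(F)cn3)C1=O)N2` is one of two members measured so far in an ADME assay on Huh-7 cells (Homo sapiens) for cytotoxicity, with a stated time of 72 h; on this read-out lower numbers stand for higher toxicity in this test and higher numbers for lower toxicity in this test. In this assay compound 1 gives > 33000 nM, which is a limit of the assay and not a number. Compound 2 `CS(=O)(=O)Nc1ccc2c(c1)S(=O)(=O)N=C(C1=C(O)C3CCCCC3N(Cc3ccc(F)cc3)C1=O)N2`, the other measured member, also gives in this assay > 33000 nM, again a limit rather than a number. Both measured values therefore sit at the limit of > 33000 nM in this assay, at which 2 of the 2 values shown sit, so within the numbers shown compound 1 cannot be placed above or below compound 2, and no step between measured compounds is available.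

Compound 3 `CS(=O)(=O)Nc1ccc2c(c1)S(=O)(=O)N=C(C1=C(O)C3CCCC3N(Cc3ccccn3)C1=O)N2` is not yet measured. It differs from compound 1 by hydrogen in place of fluoro on an aromatic carbon: the fluoro is removed and hydrogen is left on that aromatic carbon.

Going by the values given here, with only limits in hand, no step in this assay beyond the scatter is expected for the move from compound 1 to compound 3, and the step is estimated as a step that the limit leaves unreadable from compound 1 to compound 3. Compound 3 is accordingly expected to show 50000 nM in this assay, in the range 20000 nM to 150000 nM, most likely reported as a limit once more.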

Compound 3, half-maximal cytotoxic concentration: > 33000 nM
Compound 3: only a limit was reported; the forecaster's own chance of this, stated with the estimate: 85%; the middle value lies beyond the limit too.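

In this assay, for the compounds shown here, compound 3 gives > 33000 nM, a limit of the assay and not a number, so no step from compound 1 to compound 3 can be read: the limit of > 33000 nM in this assay, at which 3 of the 3 values shown sit. The compounds shown leave open whether compound 1 and compound 3 differ at all in this assay, and so what hydrogen in place of fluoro does on this read-out.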